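The source may report more compounds than this note shows. Statements on the series, on what has been measured and on what is new or still open speak of the compounds shown alone.

Measured compounds:
compound 1 `Nc1ccc(C(=O)/C=C/c2ccc(Cl)cc2)cc1`, 41%
compound 2 `Nc1ccc(C(=O)/C=C/c2ccco2)cc1`, 33%

Of the compounds shown here, two have been measured in a functional assay on the whole organism (strain albino) for inhibition, with Rattus norvegicus as the target, read by paw edema, with stated times of 30 min and 1 h, at a dose of 100 mg/kg by the oral route; on this read-out higher numbers stand for more inhibition at the one dose given (going by the name of the read-out) and lower numbers for less inhibition. Compound 1 `Nc1ccc(C(=O)/C=C/c2ccc(Cl)cc2)cc1` gives 41% in this assay, and compound 2 `Nc1ccc(C(=O)/C=C/c2ccco2)cc1` gives 33%. The gap between these two numbers lies within the scatter of repeated measurements of this kind, so the two compounds cannot be told apart on this read-out. Among the compounds with values here, no step between measured compounds is defined here; there is only the pair of values.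

Compound 3 `O=C(CBr)Nc1ccc(C(=O)/C=C/c2ccco2)cc1` has not yet been measured. It differs from compound 2 by one change: (bromomethyl)carbonyl in place of hydrogen on a nitrogen on an aromatic ring. Within the data shown here, the amino group of compound 2 thus becomes a ((bromomethyl)carbonyl)amino group in compound 3, the nitrogen on the aromatic ring keeping its one aromatic carbon neighbour.

Among the measured compounds shown here, with only two measured compounds, and these within the scatter of each other, nothing in the data tells how this change should move the read-out. The expected step from compound 2 to compound 3 is therefore a number 5 percentage points higher from compound 2 to compound 3 (within the scatter), which is not beyond the scatter. Compound 3 is estimated to give 38% in this assay, with a range from 20% to 58%.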

Compound 3, a percentage reported as inhibition, in the whole organism at one dose (the size of the read-out at that dose, not a potency): 30%
Compound 3: the middle estimate sits 8 percentage points above what was measured; low and high end bracket the measured number.
By their numbers in this assay, from the lowest: compounds 3, 2 and 1 (each within the scatter of the next, the first and the last beyond it).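

In this assay, (bromomethyl)carbonyl in place of hydrogen on the nitrogen on the aromatic ring amounts to a number 3 percentage points lower from compound 2 to compound 3 (within the scatter). Within the data shown here, this is the first step read at this position, and it shows that the amino group and the ((bromomethyl)carbonyl)amino group cannot be told apart on this read-out at the one dose given, even though the new group brings in 4 heavy atoms and a carbonyl. No measurement shown here bears on why the two compounds read alike.

The compounds shown leave open whether the bromine or the carbonyl contributes anything of its own to the read-out, which a plain acetyl group, a chloroacetyl group or a dimethylaminoacetyl group on the same nitrogen would address. They also leave open whether the same change on the core of compound 1 would again give a step within the scatter, and whether a longer chain between the carbonyl and the bromine would give a step beyond it.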